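Branching the acid chain of a fatty acid receptor agonist

This account rests on a few compounds, and the source may have more. Where it says the series, first, only, none or still open, it means among the compounds named here.

Compound 1 `Cc1nc(-c2ccc(C(F)(F)F)cc2)sc1CNc1ccc(CCC(=O)O)cc1`: 67.6 nM
Compound 2 `O=C(O)/C=C/c1ccc(NCc2cccc(Oc3ccccc3)c2)cc1`: 145 nM
Compound 3 `CC(Cc1ccc(NCc2cccc(Oc3ccccc3)c2)cc1)C(=O)O`: 100 nM

All three compounds were tested in a functional assay on CHO cells for agonist activity at Free fatty acid receptor 1 (Homo sapiens); on this read-out lower numbers stand for an effect already at smaller amounts and higher numbers for an effect only at larger amounts of compound. Compound 1 gives the lowest of the three numbers. Compound 3 lies nearest to it, and the gap between them is within the scatter, so the two cannot be ordered. Compound 2 lies furthest from compound 1, and that gap is beyond the scatter.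

The unmeasured compound 4 `Cc1nc(-c2ccc(C(F)(F)F)cc2)sc1CNc1ccc(C(C)CC(=O)O)cc1` keeps the core of compound 1 and alters only the acid chain: methyl in place of hydrogen on a saturated chain carbon bound to an aromatic carbon and a saturated chain carbon. Going by the values given here, the single step available between measured compounds also touches the acid chain, though in a different way: a 1.5-fold lower number from compound 2 to compound 3 (0.16 log units; within the scatter). That change, which likewise adds a methyl while saturating the chain, left the number within the scatter. Among the compounds with values here, no measured pair shows the exact change from compound 1 to compound 4, so the expectation rests on that one step and on the chain being otherwise unchanged. Compound 4 is therefore expected to show no step beyond the scatter, a 1.1-fold lower number from compound 1 to compound 4 (0.05 log units; within the scatter). For compound 4 the estimate in this assay is 60 nM, with a range from 25 nM to 150 nM.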

Compound 4, half-maximal effective concentration: 58.9 nM
For compound 4 the middle estimate is 1.0-fold (0.01 log units) above the measured one; low and high end bracket the measured number.
By their numbers in this assay, from the lowest: compounds 4, 1, 3 and 2 (each within the scatter of the next, the first and the last beyond it).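

With a 1.1-fold lower number from compound 1 to compound 4 (0.06 log units; within the scatter) in this assay, the piece gains its first direct reading at this position, a saturated chain carbon bound to an aromatic carbon and a saturated chain carbon. Methyl can stand in place of hydrogen there on the core of compound 1 while the number stays within the scatter. The earlier step, a 1.5-fold lower number from compound 2 to compound 3 (0.16 log units; within the scatter), joined a methyl to a saturation of the chain and so could not isolate the methyl, whereas the change from 2-carboxyethyl to 1-(carboxymethyl)ethyl isolates it, though no evidence at hand bears on why the number holds.

As far as these compounds go, whether an ethyl, a second methyl or a hydroxyl on the same carbon would also leave the number within the scatter remains open, and so does whether the methyl would behave alike on the chain of the compounds carrying the other core. The compounds shown also leave open how the two mirror-image forms of compound 4 compare, and whether this methyl matters for anything beyond this single read-out.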